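A few compounds are considered here, and "the series" means these few. Any claim that something is new, unique, unknown or untested is made for them only; others in the source may bear on it.

Measured in a functional assay on SW480 cells (Homo sapiens) for antiproliferative activity, read by MTT assay, with a stated time of 48 h; a higher number here means a weaker inhibitor, a lower number a stronger inhibitor:
- Compound 1 `CCCCCCC(CCO)n1cnc2c(Cl)nc(Cl)nc21`: 12400 nM
- Compound 2 `CCCCCCC(CCO)n1cnc2c(N)ncnc21`: > 50000 nM

Compound 2 has no exact number, as its > 50000 nM is a limit of this assay.

Compound 3 `CCCCCCC(CCO)n1cnc2c(N)nc(Cl)nc21` has not yet been measured. It keeps the amino group of compound 2 but carries chloro in place of hydrogen on an aromatic carbon, between two ring nitrogen atoms: chloro in place of hydrogen on an aromatic carbon.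

Within the data shown here, no measured pair isolates this change, so any forecast is uncertain. Compound 1 also has chloro on that carbon, and it gives a true number, 12400 nM. A modest move towards stronger inhibition is therefore expected, and the estimated step is an at least 2.2-fold lower number from compound 2 to compound 3 (0.35 log units; beyond the scatter). The expected value for compound 3 is 22000 nM, with an estimated range of 9000 nM to 50000 nM.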

Compound 3, half-maximal inhibitory concentration: > 50000 nM
Compound 3: no number, only a limit; the forecaster's own chance of this, stated with the estimate: 30%; at least 2.2-fold (0.35 log units) between middle value and limit.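

With the amino group in place, chloro on the aromatic carbon between two ring nitrogen atoms is not enough to give a true number, so the measurable activity of compound 1 does not carry over through that chloro alone. The change that can be read is amino in place of chloro on an aromatic carbon, which gives an at least 4.0-fold higher number from compound 1 to compound 3 (0.60 log units; beyond the scatter) in this assay and marks this swap as a real loss of activity. The effect of the added chloro itself cannot be read, because compound 2 and compound 3 both stop at the same limit: the limit of > 50000 nM in this assay, at which 2 of the 3 values shown sit.

On these data alone, whether chloro on this carbon has any effect at all remains open. Also open, as far as these compounds go, is whether a methylamino or methoxy group in place of amino would bring back activity like that of compound 1.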